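A Methoxyphenyl Variant of Compound 1

This account rests on a few compounds, and the source may have more. Where it says the series, first, only, none or still open, it means among the compounds named here.

Compound 1 `O=S(=O)(NCCCNCC1COc2ccccc2O1)c1cc(C(F)(F)F)cc(C(F)(F)F)c1`: 2900 nM
Compound 2 `CN(CCCNS(=O)(=O)c1cc(C(F)(F)F)cc(C(F)(F)F)c1)Cc1ccccc1`: 51000 nM
Compound 3 `O=S(=O)(NCCCNCc1ccc(Br)cc1)c1cc(C(F)(F)F)cc(C(F)(F)F)c1`: 2800 nM

All three measured compounds were tested in a functional assay on ASPC1 cells (Homo sapiens) for inhibition, read by MTT assay, with a stated time of 72 h; on this read-out higher numbers stand for weaker inhibition of growth and lower numbers for stronger inhibition of growth. In this assay compound 1 gives 2900 nM, the second highest of the three numbers. Compound 3 sits closest to it: a 1.0-fold lower number from compound 1 to compound 3 (0.02 log units; within the scatter). Among the compounds with values here, compound 2 lies furthest away; the only step involving it is an 18-fold lower number from compound 2 to compound 3 (1.26 log units; beyond the scatter), a change at the amine end of the chain rather than in the aryl group.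

Compound 4 `COc1ccc(CNCCCNS(=O)(=O)c2cc(C(F)(F)F)cc(C(F)(F)F)c2)cc1` has not yet been measured. It differs from compound 1 in one place: 4-methoxyphenyl in place of 2,3-dihydro-1,4-benzodioxin-2-yl on a saturated chain carbon bound to an amine nitrogen. The most relevant precedent is a 1.0-fold lower number from compound 1 to compound 3 (0.02 log units; within the scatter), in which the same 2,3-dihydro-1,4-benzodioxin-2-yl group was exchanged for another aryl ring on a saturated chain carbon bound to an amine nitrogen and the number did not move beyond the scatter. The large step of an 18-fold lower number from compound 2 to compound 3 (1.26 log units; beyond the scatter) concerns the amine, which compound 4 leaves unchanged, so it offers no guide here. The expectation is therefore a step no larger than the scatter, a 1.0-fold higher number from compound 1 to compound 4 (0.01 log units; within the scatter). Compound 4 is expected to give about 3000 nM, within a range from 1000 nM to 9000 nM.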

Compound 4, concentration for 50% growth inhibition: 2800 nM
Beside the measured number, compound 4's estimate is 1.1-fold (0.03 log units) above it; the range from low to high includes it.
By their numbers in this assay, from the lowest: compounds 3, 4 and 1 (each within the scatter of the next); then compound 2.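

In the growth assay, this assay, the 2,3-dihydro-1,4-benzodioxin-2-yl group can give way to a second benzene-bearing group, 4-methoxyphenyl, with no change beyond the scatter (a 1.0-fold lower number from compound 1 to compound 4 (0.02 log units; within the scatter)), so this tolerance at the saturated chain carbon bound to an amine nitrogen now rests on two exchanges rather than one. Methoxy and bromo on the aromatic carbon also cannot be told apart (no change at the digits printed from compound 3 to compound 4 (within the scatter)), even though one is built on oxygen and carbon and the other is a single halogen atom, whereas the exchange of benzyl(methyl)amino for (4-methoxybenzyl)amino is large (an 18-fold lower number from compound 2 to compound 4 (1.26 log units; beyond the scatter)), so among these compounds the large steps are the two that start from compound 2. Nothing measured here accounts for either the tolerance or the large steps.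

Going by these compounds, it remains open whether the same flat result would hold with a carboxylic acid or an amine on that aromatic carbon, where the group differs more sharply from methoxy and bromo. A longer chain joining the two nitrogens is also untested among the compounds shown, so the importance of the three-carbon link cannot be judged.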